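The source may report more compounds than this note shows. Statements on the series, on what has been measured and on what is new or still open speak of the compounds shown alone.

Working notes on a small set of compounds tested in a functional assay on MCF7 cells (Homo sapiens) for inhibition, read by MTT assay; a lower number here means a stronger inhibitor, a higher number a weaker inhibitor. Compound 1 `O=C(CCCCCCC(=O)Nc1nnc(-c2ccco2)s1)NO` gives 880 nM in this assay. Compound 2 `CC(C)=CCC/C(C)=C/CC/C(C)=C/CSc1ccccc1C(=O)NCCC(=O)NO` gives 4930 nM, and compound 3 `O=C(CCCN1CCN(C(=O)Nc2cccc3ncccc23)CC1)NO` gives 7190 nM. Compound 1 thus stands at the lowest of the three numbers; its gaps to compound 2 and to compound 3 both lie beyond the usual scatter, so among the three measured it is the strongest inhibitor. Going by the values given here, no two of the measured compounds differ in a single place, so no single-point step has yet been measured.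

Compound 4 `O=C(CCCCCCC(=O)Nc1nnc(-c2ccc(Br)o2)s1)NO` is still to be measured in this assay. It differs from compound 1 in one place: bromo in place of hydrogen on an aromatic carbon. Cut one bond further out, the change reads furan-2-yl to 5-bromofuran-2-yl, adding one heavy atom. Nothing measured here speaks to the size of such a change, so the expected step is none beyond the scatter, if anything slightly toward a lower number. For compound 4 the estimate is 700 nM, with an expected range from 300 nM to 1800 nM. The expected step of a 1.3-fold lower number from compound 1 to compound 4 (0.10 log units; within the scatter) is within the scatter.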

Compound 4, half-maximal inhibitory concentration: 880 nM
Estimate against measurement, compound 4: 1.3-fold (0.10 log units) below, within the range that was stated.
By their numbers in this assay, from the lowest: compounds 1 and 4 (each within the scatter of the next); then compounds 2 and 3 (each within the scatter of the next).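

Going by these compounds alone, the first single-place step gives no change at the digits printed from compound 1 to compound 4 (within the scatter) in this assay. On the aromatic carbon next to the ring oxygen, the change from furan-2-yl to 5-bromofuran-2-yl therefore adds one heavy atom without moving the number beyond the scatter, which the earlier, structurally unrelated compounds could not show. No evidence at hand gives a reason for this result.

A single halogen leaves open whether the same carbon would accept a larger or differently charged group, such as a phenyl ring, an amine or a carboxylic acid, with a similarly flat result. Going by these compounds, the effect of a shorter or longer chain on the shared core also remains open, as does whether bromo behaves the same way with such a chain.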